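Cytotoxicity on Vero Cells: From Compound 3 to Compound 4

This account rests on a few compounds, and the source may have more. Where it says the series, first, only, none or still open, it means among the compounds named here.

Measured in an ADME assay on Vero cells (Chlorocebus sabaeus) for cytotoxicity, read by MTT assay, tested at 25 uM; a higher number here means a weaker effect of the compound at the concentration tested, a lower number a stronger effect:
compound 1 `CSc1ccc(C(=O)/C(=C/c2cccnc2)c2ccc(Cl)c(Cl)c2)cc1` gives 95.7%
compound 2 `CSc1ccc(C(=O)/C(=C/c2ccccn2)c2ccc(Cl)c(Cl)c2)cc1` gives 97.9%
compound 3 `CCOC(=O)C(C(=O)c1ccc(OC)cc1)C(NC(C)=O)c1ccc(C(C)(C)C)cc1` gives 94.5%

All three measured compounds leave the cells largely untouched at the concentration tested. On these numbers compound 3 is nearest to compound 1 and furthest from compound 2, and both gaps lie within the scatter, so no ordering among the three can be read from them.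

For the measured compounds named here, the one measured step between compounds differing in a single place is a number 2.2 percentage points higher from compound 1 to compound 2 (within the scatter). That step concerns a pyridyl swap on the core shared by compound 1 and compound 2 and does not touch the part of compound 3 that is changed next.

Compound 4 `CCOC(=O)C(C(=O)c1ccc(OC)cc1)C(NC(C)=O)c1ccc(OC)c(OC)c1` differs from compound 3 in one place: 3,4-dimethoxyphenyl in place of 4-(tert-butyl)phenyl on a saturated chain carbon bound to an amide-type nitrogen and a saturated chain carbon. Going by the values given here, no measured step bears on this exchange; the account has only the flat picture given by compound 1, compound 2 and compound 3 in this assay, where every value sits near the top of the scale. On that basis the step is expected to be none beyond the scatter, a number 0.5 percentage points lower from compound 3 to compound 4 (within the scatter). Compound 4 is therefore estimated to give 94% in this assay, within a range from 84% to 100%.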

Compound 4, a percentage reported as activity, at one concentration (the size of the read-out at that concentration, not a potency): 99.1%
Compound 4: the middle estimate sits 5.1 percentage points below what was measured; measured number inside the range.
By their numbers in this assay, from the lowest: compounds 3, 1, 2 and 4 (each within the scatter of the next).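

At the saturated chain carbon bound to an amide-type nitrogen and a saturated chain carbon, replacing 4-(tert-butyl)phenyl with 3,4-dimethoxyphenyl gives, in this assay, a step that reads (a number 4.6 percentage points higher from compound 3 to compound 4 (within the scatter)). For the compounds shown here, this is the only measured change at this position, and the earlier compounds could say nothing about it: their single step concerns a pyridyl swap on a different core. It shows that an all-carbon group can give way here to one that brings oxygen and hydrogen-bond acceptors without a shift beyond the scatter, so the flat picture of the earlier compounds extends to this exchange; nothing measured here accounts for the size of the step.

From the compounds shown here alone, the two compounds cover only these aryl groups at this position, and both share the ethyl ester, the acetamide and the 4-methoxyphenyl ketone, so the contribution of those parts remains untested. Going by these compounds, it stays open whether a primary amine or a carboxylic acid on the ring at this position would move the number beyond the scatter, or whether the picture would stay as flat as it is across these compounds.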